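A few compounds are considered here, and "the series" means these few. Any claim that something is new, unique, unknown or untested is made for them only; others in the source may bear on it.

Measured in a functional assay on A549 cells (Homo sapiens) for inhibition, read by MTT assay, with a stated time of 48 h; a lower number here means a stronger inhibitor, a higher number a weaker inhibitor:
Compound 1 `COc1ccc(N(C)c2nc(C)nc3ccccc23)cc1C(=O)NCC[Se]C#N`: 187 nM
Compound 2 `COc1ccc(N(C)c2nc(C)nc3ccccc23)cc1[Se]C`: 11 nM

Compound 2 has the lower of the two numbers. Compound 3 `COc1ccc(N(C)c2nc(C)nc3ccccc23)cc1C(=O)OCCCC[Se]C#N` has a much larger group at the same place on the shared core: a group of 10 heavy atoms (6 carbon, 1 nitrogen, 2 oxygen, 1 selenium; no ring) in place of a group of 2 heavy atoms (1 carbon, 1 selenium; no ring), on an aromatic carbon. Among the compounds with values here, one measured step bears on this, a 17-fold lower number from compound 1 to compound 2 (1.23 log units; beyond the scatter), and it shrinks a large group to the small one that compound 3 lacks. Compound 3 resembles compound 1, at 187 nM, in carrying a long group, so a large rise in this assay is expected. The expected change is a 12-fold higher number from compound 2 to compound 3 (1.07 log units; beyond the scatter). Compound 3 is estimated at 130 nM, with an expected range of 35 nM to 500 nM.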

Compound 3, half-maximal inhibitory concentration: 155 nM
Estimate against measurement, compound 3: 1.2-fold (0.08 log units) below, within the range that was stated.
By their numbers in this assay, from the lowest: compound 2; then compounds 3 and 1 (each within the scatter of the next).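

In this assay, compound 3 places a second long group on this aromatic carbon, and the outcome is a 14-fold higher number from compound 2 to compound 3 (1.15 log units; beyond the scatter), so the high number no longer rests on compound 1 alone. Replacing the amide link with an ester and a longer chain, at the carbonyl carbon, gives a 1.2-fold lower number from compound 1 to compound 3 (0.08 log units; within the scatter), so this change does not separate the two long groups. Nothing measured here explains either step. Still open, from the compounds shown here alone, is whether a carboxylic acid or an amine on this carbon would fall nearer compound 2 or compound 3. Going by these compounds, it is also open whether a long chain ending in a methyl group on selenium, rather than a nitrile, would keep the lower number.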